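The source may report more compounds than this note shows. Statements on the series, on what has been measured and on what is new or still open speak of the compounds shown alone.

Measured so far:
- compound 1, `Cc1cc(-c2ccccc2)n(/C(N)=N/S(=O)(=O)c2cc(C)c(Cl)cc2SCc2ccccc2C(F)(F)F)n1`, 215000 nM
- compound 2, `Cc1cc(S(=O)(=O)/N=C(\N)n2nccc2-c2ccccc2)c(SCc2ccccc2C)cc1Cl`, 17000 nM
- compound 3, `Cc1cc(S(=O)(=O)/N=C(\N)n2nccc2-c2ccccc2)c(SCc2cccc(C(F)(F)F)c2)cc1Cl`, 19000 nM

The read-out throughout is a functional assay on HeLa cells (Homo sapiens) for cytotoxicity, read by MTT assay, with a stated time of 72 h; on this read-out lower numbers stand for stronger inhibition and higher numbers for weaker inhibition. Among the three numbers compound 3 stands second highest; its nearest neighbour is compound 2, which differs only in the group on the saturated chain carbon bound to a sulfur, and the step of a 1.1-fold higher number from compound 2 to compound 3 (0.05 log units; within the scatter) lies within the scatter. Within the data shown here, compound 1 lies far from both, but it carries a different core, and no single-point step connects it to compound 3.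

Compound 4, `Cc1cc(S(=O)(=O)/N=C(\N)n2nccc2-c2ccccc2)c(SCc2ccccc2C(F)(F)F)cc1Cl`, is the next point. Relative to compound 3 it changes: 2-(trifluoromethyl)phenyl in place of 3-(trifluoromethyl)phenyl on a saturated chain carbon bound to a sulfur. Among the measured compounds shown here, the one measured step at the same place, a 1.1-fold higher number from compound 2 to compound 3 (0.05 log units; within the scatter), was flat, so there is no sign that swapping the group on this carbon moves the number. Compound 1 carries the same 2-(trifluoromethyl)phenyl on its own core and gives 215000 nM, but its core differs, so that value is only a loose caution. The expected step of a 1.3-fold higher number from compound 3 to compound 4 (0.12 log units; within the scatter) is therefore none beyond the scatter. Compound 4 is estimated at 25000 nM, within 9000 nM to 70000 nM.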

Compound 4, half-maximal inhibitory concentration: 20000 nM
Compound 4: middle estimate off by 1.3-fold (0.10 log units), on the high side, and the stated range covers the measured number.
By their numbers in this assay, from the lowest: compounds 2, 3 and 4 (each within the scatter of the next); then compound 1.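

In this assay, 2-(trifluoromethyl)phenyl in place of 3-(trifluoromethyl)phenyl on a saturated chain carbon bound to a sulfur gives a 1.1-fold higher number from compound 3 to compound 4 (0.02 log units; within the scatter) and trifluoromethyl in place of methyl on an aromatic carbon gives a 1.2-fold higher number from compound 2 to compound 4 (0.07 log units; within the scatter); neither change separates these compounds. The change elsewhere, hydrogen in place of methyl on an aromatic carbon, gives an 11-fold lower number from compound 1 to compound 4 (1.03 log units; beyond the scatter) and is beyond the scatter, so 2-(trifluoromethyl)phenyl alone does not carry the high number of compound 1. No measurement on hand explains either the flat steps or the large one.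

Open, going by these compounds, is whether a carboxylic acid, an amine or a longer alkyl chain on the sulfur-bound carbon would also leave the number unchanged. Also open, on these data alone, is whether the large methyl step recurs with other groups at that carbon.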